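A triazole ester series where the assay floor hides differences

The source may report more compounds than this note shows. Statements on the series, on what has been measured and on what is new or still open speak of the compounds shown alone.

Compound 2 `COc1ccccc1-n1cc(COC(=O)/C(C)=C/CC/C(C)=C/CC/C(C)=C/CC[C@@H]2[C@@]3(C)CCC(=O)C(C)(C)[C@H]3CC[C@@]2(C)O)nn1` carries a 2-methoxyphenyl on the triazole nitrogen of the shared core. In a functional assay on DU-145 cells (Homo sapiens) for antiproliferative activity, read by MTT assay, with a stated time of 48 h (a lower number here means a stronger inhibitor, a higher number a weaker inhibitor), compound 2 gives only a limit, > 150000 nM. Compound 1 `C/C(=C\CC/C(C)=C/CC[C@@H]1[C@@]2(C)CCC(=O)C(C)(C)[C@H]2CC[C@@]1(C)O)CC/C=C(\C)C(=O)OCc1cn(-c2ccc(F)cc2)nn1` is its 4-fluorophenyl counterpart. In this assay compound 1 likewise reaches only the limit, > 150000 nM. Compound 3 `C/C(=C\CC/C(C)=C/CC[C@@H]1[C@@]2(C)CCC(=O)C(C)(C)[C@H]2CC[C@@]1(C)O)CC/C=C(\C)C(=O)OCc1cn(-c2ccc(F)c(Cl)c2)nn1` bears a 3-chloro-4-fluorophenyl. In this assay compound 3 also stops at the limit, > 150000 nM. The steps among them, a step that the two limits leave unreadable from compound 1 to compound 2, a step that the two limits leave unreadable from compound 1 to compound 3 and a step that the two limits leave unreadable from compound 2 to compound 3, therefore cannot be sized, because the limit of > 150000 nM in this assay, at which 3 of the 3 values shown sit, places every measured value at the same floor.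

Compound 4 `C/C(=C\CC/C(C)=C/CC[C@@H]1[C@@]2(C)CCC(=O)C(C)(C)[C@H]2CC[C@@]1(C)O)CC/C=C(\C)C(=O)OCc1cn(-c2cccc(O)c2)nn1` is the next member of the set. Its change from compound 2 is 3-hydroxyphenyl in place of 2-methoxyphenyl on an aromatic nitrogen. For the measured compounds named here, no measured step can be read, so there is nothing to project onto this change in either direction beyond the scatter. Going by the values given here, the only guide is that all three neighbours of compound 4 sit at the limit, which makes a further limit the most likely outcome. On that basis compound 4 is expected to give about 200000 nM in this assay, within 80000 nM to 600000 nM, and the step it implies, a step that the limit leaves unreadable from compound 2 to compound 4, is expected to be unreadable as well.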

Compound 4, half-maximal inhibitory concentration: 28400 nM
For compound 4 the middle estimate is 7.0-fold (0.85 log units) above the measured one; the whole stated range lies above it.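

In this assay the group on the aromatic nitrogen proves able to move the result: 3-hydroxyphenyl gives an at least 5.2-fold lower number from compound 2 to compound 4 (0.72 log units; beyond the scatter), and the same group gives an at least 5.2-fold lower number from compound 3 to compound 4 (0.72 log units; beyond the scatter) and an at least 5.2-fold lower number from compound 1 to compound 4 (0.72 log units; beyond the scatter). Compound 4 is also the only one of the four whose group at this position counts a hydrogen-bond donor, although four compounds are too few to establish that as a pattern. The steps among compound 1, compound 2 and compound 3 still cannot be read, and the full size of the three new steps stays hidden, because the reference compounds give no number: the limit of > 150000 nM in this assay, at which 3 of the 4 values shown sit.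

The compounds shown leave open whether the change depends on the hydroxyl itself or on where it sits, since compound 4 differs from compound 2 in both the group and its place on the ring, and a 3-methoxyphenyl or a 4-hydroxyphenyl group would help to separate the two. They also leave open whether another group at the same place on the ring, such as an amine or a carboxylic acid, would give a readable value.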